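Trimethoxyphenyl Cyclopentenones: Allyloxy Replaced by Benzamido

The compounds below may be only part of what the source reports. "The series", "measured", "known", "first", "only" and "open" are said of these compounds alone.

Compound 1, `COc1ccc(C2=C(c3cc(OC)c(OC)c(OC)c3)C(=O)C(O[SiH2]C(C)(C)C)C2)cc1OC(C)C`: 7.1 ug/mL
Compound 2, `C=CCOc1cc(C2=C(c3cc(OC)c(OC)c(OC)c3)C(=O)C(O)C2)ccc1OC`: > 100 ug/mL, a limit of the assay, not a number

In an ADME assay on HEp-2 cells (Homo sapiens) for cytotoxicity, read by MTT assay, with a stated time of 72 h (on this read-out lower numbers stand for stronger inhibition and higher numbers for weaker inhibition), compound 1 gives 7.1 ug/mL. Compound 2 sits at the limit of > 100 ug/mL in this assay, at which 1 of the 2 values shown sits, so for compound 2 only a limit is known and no number. Compound 3, `COc1ccc(C2=C(c3cc(OC)c(OC)c(OC)c3)C(=O)C(O)C2)cc1NC(=O)c1ccccc1`, has not yet been measured. It differs from compound 2 in one place: benzamido in place of allyloxy on an aromatic carbon. No step between two measured compounds joins this pair, so the size of the change can only be expected, not shown.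

In this assay the step from compound 2 to compound 3 is expected to be small, within the usual scatter, an at least 1.6-fold lower number from compound 2 to compound 3 (0.22 log units; that floor lies within the scatter). Compound 3 is therefore expected to give about 60 ug/mL, with a range from 20 ug/mL to 150 ug/mL, and a fair chance that the assay again reports only a limit.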

Compound 3, half-maximal inhibitory concentration: > 100 ug/mL
Compound 3 gave a limit, no number; the forecaster's own chance of this, stated with the estimate: 40%; middle value at least 1.6-fold (0.22 log units) from the limit.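

In this assay compound 3 gives > 100 ug/mL, a limit of the assay and not a number. Compound 2 also stands at a limit, so no step can be read between compound 2 and compound 3: the limit of > 100 ug/mL in this assay, at which 2 of the 3 values shown sit.

The compounds shown leave open whether benzamido in place of allyloxy on an aromatic carbon changes the value at all.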